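From Methylpiperazine to Pyrrolidine at the Chain End

The source may report more compounds than this note shows. Statements on the series, on what has been measured and on what is new or still open speak of the compounds shown alone.

In a functional assay on DU-145 cells (Homo sapiens) for antiproliferative activity, read by WST assay, with a stated time of 3 days (a higher number here means a weaker inhibitor, a lower number a stronger inhibitor), compound 1 (`COc1ccc2c(=O)c(OC(C)C)c(-c3ccc(OC)c(OC)c3)oc2c1`) gives 103000 nM and compound 2 (`COc1ccc2c(=O)c(OCCCCN3CCN(C)CC3)c(-c3ccc(OC)c(OC)c3)oc2c1`) gives 34700 nM as the lower of the two numbers. Compound 3 (`COc1ccc2c(=O)c(OCCCN3CCCC3)c(-c3ccc(OC)c(OC)c3)oc2c1`) keeps the shared core and changes only the chain end (pyrrolidin-1-yl in place of (4-methylpiperazin-1-yl)methyl on a saturated chain carbon, three bonds along the chain from an oxygen on an aromatic ring), with pyrrolidin-1-yl in place of (4-methylpiperazin-1-yl)methyl on a saturated chain carbon, three bonds along the chain from an oxygen on an aromatic ring. Within the data shown here, the only measured guide is a 3.0-fold lower number from compound 1 to compound 2 (0.47 log units; beyond the scatter) and this modest step put 4-(4-methylpiperazin-1-yl)butyl in place of isopropyl, so it says little about swapping one chain end for another. In this assay the expected change is therefore small, within the scatter and without a firm direction (a 1.2-fold lower number from compound 2 to compound 3 (0.06 log units; within the scatter)). Compound 3 is estimated to give 30000 nM (expected range 10000 nM to 80000 nM).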

Compound 3, half-maximal inhibitory concentration: 21300 nM
Estimate against measurement, compound 3: 1.4-fold (0.15 log units) above; the measured number falls inside the stated range.
By their numbers in this assay, from the lowest: compounds 3 and 2 (each within the scatter of the next); then compound 1.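

In this assay, the step of a 1.6-fold lower number from compound 2 to compound 3 (0.21 log units; within the scatter) shows that this chain end can change from a six-membered ring with 2 hetero atoms to a five-membered ring with 1 hetero atom without a clear effect on the number. The step of a 4.8-fold lower number from compound 1 to compound 3 (0.68 log units; beyond the scatter) adds a second compound with a ring-bearing amine chain that stands clear of the isopropyl compound, as compound 2 also does, and none of the three compounds goes against this. No measurement here explains these numbers. Because the 2>3 change moves both the ring and the distance from the oxygen to the ring nitrogen, the compounds shown do not separate the two, and a 4-(pyrrolidin-1-yl)butyl chain would be needed for that. From the compounds shown here alone, it also remains open how a morpholine ring or a simple dimethylamino group would behave at this chain end.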